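A few compounds are considered here, and "the series" means these few. Any claim that something is new, unique, unknown or untested is made for them only; others in the source may bear on it.

Measured compounds in an ADME assay on microsomes from liver (Mus musculus) for metabolic stability, read by LC-MS, with a stated time of 30 min, tested at 1 uM; on this read-out lower numbers stand for a less stable compound and higher numbers for a more stable compound:
- Compound 1, `O=C(NCc1ccc(S(=O)(=O)c2ccccc2)cc1)c1nc2ccncc2s1`, gives 26%.
- Compound 2, `O=C(NCc1ccc(S(=O)(=O)c2cccc(C(F)(F)F)c2)cc1)c1cc2ccncc2o1`, gives 64%.
- Compound 3, `O=C(NCc1ccc(S(=O)(=O)N2CCCCC2)cc1)c1cc2ccncc2o1`, gives 0.14%.

Among these three numbers compound 1 stands second highest: compound 3 lies beyond the scatter below it, and compound 2 lies beyond the scatter above it. Compound 4, `O=C(NCc1ccc(S(=O)(=O)c2ccccc2)cc1)c1cnc2nccn2c1`, has not yet been measured in this assay . It differs from compound 1 on a carbonyl carbon whose other neighbours are an amide-type nitrogen: a group of 9 heavy atoms (6 carbon, 3 nitrogen; one five-membered aromatic ring with 2 hetero atoms, one six-membered aromatic ring with 2 hetero atoms) in place of a group of 9 heavy atoms (6 carbon, 2 nitrogen, 1 sulfur; one five-membered aromatic ring with 2 hetero atoms, one six-membered aromatic ring with 1 hetero atom), on a carbonyl carbon.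

Within the data shown here, the one measured step, a number 63.9 percentage points lower from compound 2 to compound 3 (beyond the scatter), concerns the group on the sulfonyl sulfur and so does not bear on the change from compound 1 to compound 4. Compound 1 and compound 2 differ in two places at once, so their values only show that two different groups on the carbonyl carbon can sit far apart in this assay , without telling which part of that difference matters. Among the measured compounds shown here, no measured step therefore guides the direction for compound 4, and a step of uncertain sign is expected, a number 9 percentage points higher from compound 1 to compound 4 (within the scatter). Compound 4 is estimated at 35%, within a wide range from 8% to 70%.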

Compound 4, percent of the compound remaining: 30%
Beside the measured number, compound 4's estimate is 5 percentage points above it; low and high end bracket the measured number.
By their numbers in this assay, from the lowest: compound 3; then compounds 1 and 4 (each within the scatter of the next); then compound 2.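

Among these compounds, with the rest of compound 1 held fixed, the exchange on the carbonyl carbon gives a number 4 percentage points higher from compound 1 to compound 4 (within the scatter) in this assay, the first step at this position that can be read on its own. It shows that a sulfur-containing group and a group of carbon and nitrogen alone, each of 9 heavy atoms with two aromatic rings, can stand on this carbonyl carbon without a separation beyond the scatter. No measurement of any property of these groups accompanies this result.

The compounds shown leave open whether the same exchange would read alike with 3-(trifluoromethyl)phenyl or piperidin-1-yl on the sulfonyl sulfur. They also leave open how a single ring on the carbonyl carbon, such as plain phenyl or pyridine, would compare with compound 1.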